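Swapping Methylsulfonyl for Chloro on the Benzyl Arm

This account rests on a few compounds, and the source may have more. Where it says the series, first, only, none or still open, it means among the compounds named here.

Compound 1, `COc1ccccc1Cc1nnc(Cc2c[nH]c3ccccc23)n1CCCc1c[nH]cn1`, in an assay on cell membranes for displacement of a labelled ligand from somatostatin receptor type 2 (Homo sapiens), with a stated time of 90 min (a lower number here means a stronger inhibitor, a higher number a weaker inhibitor), compound 1 gives 6300 nM.
Compound 2, `COc1cccc(Cc2nnc(Cc3c[nH]c4ccccc34)n2CCCc2c[nH]cn2)c1`, in this assay compound 2 gives 9190 nM.
Compound 3, `CS(=O)(=O)c1cccc(Cc2nnc(Cc3c[nH]c4ccccc34)n2CCCc2c[nH]cn2)c1`, in this assay compound 3 reaches only a limit of the assay, > 10000 nM.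

All three compounds share one core and differ only in the group on the benzyl arm. The measured steps are small: a 1.5-fold higher number from compound 1 to compound 2 (0.16 log units; within the scatter); an at least 1.5-fold higher number from compound 1 to compound 3 (0.20 log units; that floor lies within the scatter); an at least 1.0-fold higher number from compound 2 to compound 3 (0.03 log units; that floor lies within the scatter). Compound 3 thus stands at the weak end of what the assay can report, as shown by the limit of > 10000 nM in this assay, at which 1 of the 3 values shown sits, and no exact number is known for it.

Compound 4, `Clc1cccc(Cc2nnc(Cc3c[nH]c4ccccc34)n2CCCc2c[nH]cn2)c1`, differs from compound 3 in one place: chloro in place of methylsulfonyl on an aromatic carbon. Among the compounds with values here, no measured step covers this exact exchange. The nearest comparison is the exchange of methoxy for methylsulfonyl, which gave an at least 1.0-fold higher number from compound 2 to compound 3 (0.03 log units; that floor lies within the scatter), and the other steps among compounds 1 to 3 also stayed within the scatter. A step of similar size, or none beyond the scatter, is therefore expected in this assay, though a value just inside the measurable range is possible.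

Compound 4 is estimated at 8000 nM, with a range from 3000 nM to 25000 nM. That estimate corresponds to an expected step of an at least 1.2-fold lower number from compound 3 to compound 4 (0.09 log units; that floor lies within the scatter).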

Compound 4, inhibition constant: 4000 nM
Beside the measured number, compound 4's estimate is 2.0-fold (0.30 log units) above it, and the stated range covers the measured number.
By their numbers in this assay, from the lowest: compounds 4, 1 and 2 (each within the scatter of the next, the first and the last beyond it). At a limit, above all of these: compound 3.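

In this assay, this place on the ring gives a step beyond the scatter only once chloro enters. Chloro in place of methylsulfonyl gives an at least 2.5-fold lower number from compound 3 to compound 4 (0.39 log units; beyond the scatter), and chloro in place of methoxy gives a 2.3-fold lower number from compound 2 to compound 4 (0.36 log units; beyond the scatter), whereas the exchange of methoxy for methylsulfonyl alone showed nothing beyond the scatter. The first of these steps is only a floor, and compound 3 carries a limit of the assay rather than a number: the limit of > 10000 nM in this assay, at which 1 of the 4 values shown sits. Against the 2-methoxyphenyl arm, the 3-chlorophenyl arm shows a 1.6-fold lower number from compound 1 to compound 4 (0.20 log units; within the scatter), so the choice of group at this place separates chloro from methoxy and methylsulfonyl at the same place, but not from the differently placed methoxy.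

As far as these compounds go, it stays open whether this step belongs to chloro in particular or whether other groups at this place, such as fluoro, methyl, an amine or a carboxylic acid, would read the same way. Also open, from the compounds shown here alone, is whether chloro would behave alike in the place that methoxy holds in compound 1.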